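Series notes: from compound 3 to compound 4

The source may report more compounds than this note shows. Statements on the series, on what has been measured and on what is new or still open speak of the compounds shown alone.

Measured in a functional assay on A549 cells (Homo sapiens) for inhibition, read by MTT assay, with a stated time of 72 h; a higher number here means a weaker inhibitor, a lower number a stronger inhibitor:
- compound 1 `COc1cc(N(C)CCN(C)C)c(NC(=O)C=C(C)C)cc1Nc1nc2c(c(-c3cn(C)c4ccccc34)n1)CSCC2`: 583 nM
- compound 2 `C=CC(=O)Nc1cc(Nc2nc3c(c(-c4cn(C)c5ccccc45)n2)CS(=O)(=O)CC3)c(OC)cc1N(C)CCN(C)C`: 8690 nM
- compound 3 `C=C(Cl)C(=O)Nc1cc(Nc2nc3c(c(-c4cn(C)c5ccccc45)n2)CS(=O)(=O)CC3)c(OC)cc1N(C)CCN(C)C`: 881 nM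

Compound 3 lies within the usual scatter of compound 1 and well under compound 2 on these numbers. The next compound to be read is compound 4 `COc1cc(N(C)CCN(C)C)c(NC(=O)C=C(C)C)cc1Nc1nc2c(c(-c3cn(C)c4ccccc34)n1)CS(=O)(=O)CC2`, which carries 2-methylprop-1-en-1-yl in place of 1-chloroethenyl on a carbonyl carbon.

For the measured compounds named here, only one measured step falls at this place: a 9.9-fold lower number from compound 2 to compound 3 (0.99 log units; beyond the scatter). It shows that the number can move strongly with a change here, but it does not cover this exchange. Compound 1 carries the incoming 2-methylprop-1-en-1-yl and gives 583 nM on a different core, so it is only a loose guide. Compound 2 and compound 3 share their core with compound 4. A modest step toward a higher number is therefore expected in this assay: the estimate is a 2.0-fold higher number from compound 3 to compound 4 (0.31 log units; beyond the scatter) and remains uncertain.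

The expected value for compound 4 is 1800 nM within an estimated range of 550 nM to 6000 nM on repeat measurement.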

Compound 4, half-maximal inhibitory concentration: 787 nM
Compound 4: middle estimate off by 2.3-fold (0.36 log units), on the high side; measured number inside the range.
By their numbers in this assay, from the lowest: compounds 1, 4 and 3 (each within the scatter of the next); then compound 2.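

In this assay, on the shared core, 1-chloroethenyl and 2-methylprop-1-en-1-yl on the carbonyl carbon cannot be told apart: a 1.1-fold lower number from compound 3 to compound 4 (0.05 log units; within the scatter). Vinyl at the same place is the outlier, with an 11-fold lower number from compound 2 to compound 4 (1.04 log units; beyond the scatter), so the gain seen earlier with the chloro exchange, a 9.9-fold lower number from compound 2 to compound 3 (0.99 log units; beyond the scatter), does not depend on chlorine and is also reached by a group made only of carbon and hydrogen. Nothing at hand bears on why the vinyl compound stands apart from the other two.

The compounds shown leave open whether a single methyl on the double bond, or a dimethylaminomethyl group at its end, would behave in the same way on this core. Also open, as far as these compounds go, is how the core of compound 1 would read with vinyl or 1-chloroethenyl, as compound 1 carries only 2-methylprop-1-en-1-yl.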